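The source may report more compounds than this note shows. Statements on the series, on what has been measured and on what is new or still open speak of the compounds shown alone.

Three compounds have so far been measured in a functional assay on CHO cells for agonist activity at Free fatty acid receptor 1 (Homo sapiens), read by reporter gene assay; a lower number here means a smaller maximal response, a higher number a larger maximal response:

Compound 1 `O=C(O)CCc1ccc(NCc2ccc(-c3ccccc3)cc2)cc1`: 111%
Compound 2 `O=C(O)CCc1cccc(NCc2ccc(-c3ccccc3)cc2)c1`: 160%
Compound 3 `O=C(O)CCCc1ccc(NCc2ccc(-c3ccccc3)cc2)cc1`: 62%

Among these three, compound 1 stands second highest. Compound 2 lies above it by a gap beyond the usual scatter, and compound 3 lies below it, the step of a number 49 percentage points lower from compound 1 to compound 3 (beyond the scatter) being likewise beyond the scatter. That step comes from carboxymethyl in place of carboxy on a saturated chain carbon, two bonds along the chain from an aromatic carbon.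

Compound 4 `O=C(O)CCc1ccc(NCc2ccccc2)cc1` has not yet been measured. It differs from compound 1 in one place: hydrogen in place of phenyl on an aromatic carbon. Going by the values given here, none of the measured steps touches this part of the molecule; the single step on record alters the acid-bearing chain instead, so it offers no direct guide. Among the compounds with values here, with no comparable step to lean on, the expectation for compound 4 rests only on the loss of the phenyl itself and is therefore uncertain: compound 4 is expected to give 60%, with a likely range from 20% to 110%. This corresponds to an expected step of a number 51 percentage points lower from compound 1 to compound 4 (beyond the scatter) in this assay.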

Compound 4, largest response reached (reported as percent of maximum), in percent of the reference or control that the assay uses: 144%
Beside the measured number, compound 4's estimate is 84 percentage points below it, outside the stated range (above it).
By their numbers in this assay, from the lowest: compound 3; then compound 1; then compound 4; then compound 2.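

The phenyl on this aromatic carbon is not required for a large maximal response in this assay: with hydrogen in its place, the result is a number 33 percentage points higher from compound 1 to compound 4 (beyond the scatter). Removing this whole outer ring therefore raises the response, whereas the only other change shown from compound 1, at the acid-bearing chain, gives a number 49 percentage points lower from compound 1 to compound 3 (beyond the scatter). Nothing measured here explains why the response rises when the phenyl is lost.

The compounds shown leave open how a small group at this position, such as methyl or chlorine, would compare with hydrogen and phenyl. They also leave open whether losing the phenyl would have the same effect in compound 2 or in compound 3, which has the longer acid-bearing chain.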